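Methoxy for Trifluoromethyl on the Pendant Ring

The source may hold more compounds than are shown below. What is called first, only, known or untested is meant among the compounds shown, and "the series" means these compounds.

Measured so far:
- compound 1, `C=CCOc1ccc(-c2ccc(OC)cc2)cc1CC=C`: > 100000 nM
- compound 2, `C=CCc1cc(-c2cccc(C(F)(F)F)c2)ccc1O`: 65900 nM
- compound 3, `C=CCc1cc(C=O)c(OCC(=O)OCC)c(-c2ccc(OCC(=O)OCC)c(CC=C)c2)c1`: 26100 nM

Of the compounds shown here, three have been tested in a functional assay on Lewis lung carcinoma cells (Mus musculus) for antiproliferative activity, read by MTT assay, with a stated time of 24 h; on this read-out higher numbers stand for weaker inhibition and lower numbers for stronger inhibition. Compound 2 gives 65900 nM, the higher of the two numbers obtained, so among them it is the weaker inhibitor. Compound 3 gives 26100 nM, a lower number, and the gap between the two lies beyond the usual scatter. Among the compounds with values here, for compound 1 the result is a limit of the assay rather than a number, > 100000 nM; it is the one value that sits at the limit of > 100000 nM in this assay, at which 1 of the 3 values shown sits.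

The next compound, compound 4 `C=CCc1cc(-c2cccc(OC)c2)ccc1O`, is not yet measured. It differs from compound 2 in one place: methoxy in place of trifluoromethyl on an aromatic carbon. Nothing measured here isolates this exchange, so no step size can be read from the data. The expectation for the step from compound 2 to compound 4 in this assay is a 1.4-fold higher number from compound 2 to compound 4 (0.14 log units; within the scatter), a change roughly within the scatter, possibly toward weaker inhibition. Compound 4 is thus estimated at 90000 nM, with a range from 30000 nM to 300000 nM.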

Compound 4, half-maximal inhibitory concentration: > 100000 nM
Compound 4: only a limit was reported; the forecaster's own chance of this, stated with the estimate: 40%; middle value at least 1.1-fold (0.04 log units) from the limit.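

Within the data shown here, this is the first exchange at this position that can be read in this assay: methoxy in place of trifluoromethyl on an aromatic carbon gives an at least 1.5-fold higher number from compound 2 to compound 4 (0.18 log units; that floor lies within the scatter). Compound 4 gives > 100000 nM, which is a limit and not a number, so the step has a floor but no measured size, and methoxy shows no gain in inhibition here. The result adds a second value at the limit of this read-out: the limit of > 100000 nM in this assay, at which 2 of the 4 values shown sit.

As far as these compounds go, whether an amine or a nitrile on this same aromatic carbon would give a lower number than trifluoromethyl remains open. Also open, from the compounds shown here alone, are the true size of this step and whether the same exchange would behave alike on a different core.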